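Chloro to trifluoromethyl on the aryl ring of compound 1

This account rests on a few compounds, and the source may have more. Where it says the series, first, only, none or still open, it means among the compounds named here.

Measured compounds in an ADME assay on Huh-7 cells (Homo sapiens) for cytotoxicity; a higher number here means that more compound is tolerated, a lower number that less compound is tolerated:
Compound 1 `CN1CCN(CCCNCc2cn(-c3ccc([N+](=O)[O-])cc3)nc2-c2ccc(Cl)cc2)CC1` gives 3700 nM.
Compound 2 `Cc1ccccc1-c1nn(-c2ccc(Br)cc2)cc1CNCCN1CCN(C)CC1` gives 9600 nM.
Compound 3 `CN1CCN(CCNCc2cn(-c3ccc([N+](=O)[O-])cc3)nc2-c2ccc(Cl)cc2)CC1` gives 5000 nM.

Compound 1 stands lowest of these three numbers. Its nearest neighbour is compound 3, reached by the step of a 1.4-fold higher number from compound 1 to compound 3 (0.13 log units; within the scatter). Compound 2 lies furthest away; compound 2 and compound 1 differ in more than one place, so only their two values can be compared, and they lie beyond the scatter of each other.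

Compound 4 `CN1CCN(CCCNCc2cn(-c3ccc([N+](=O)[O-])cc3)nc2-c2ccc(C(F)(F)F)cc2)CC1` arises from compound 1 by the change (trifluoromethyl in place of chloro on an aromatic carbon). Among the measured compounds shown here, none of the measured steps touches this position of the shared core: the only step known, from compound 1 to compound 3, concerns the chain to the piperazine and was within the scatter. For the measured compounds named here, no measured pair therefore bears on the exchange of chloro for trifluoromethyl, and there is no basis for expecting a step beyond the scatter in this assay. Compound 4 is accordingly estimated at 3700 nM, within a range from 1500 nM to 9000 nM, which means an expected step of no change at the digits printed from compound 1 to compound 4 (within the scatter).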

Compound 4, half-maximal cytotoxic concentration: 4900 nM
Beside the measured number, compound 4's estimate is 1.3-fold (0.12 log units) below it; measured number inside the range.
By their numbers in this assay, from the lowest: compounds 1, 4, 3 and 2 (each within the scatter of the next, the first and the last beyond it).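

In this assay, the exchange of chloro for trifluoromethyl on an aromatic carbon, para to a large group, gives a 1.3-fold higher number from compound 1 to compound 4 (0.12 log units; within the scatter). Among the compounds shown here, this is the first single-place reading at this position of the shared core, where the only earlier step, a 1.4-fold higher number from compound 1 to compound 3 (0.13 log units; within the scatter), concerned the chain to the piperazine, and it shows that a group of 4 heavy atoms can stand in place of a single chlorine without a step beyond the scatter. No measurement at hand accounts for this outcome.

The compounds shown leave open whether a group of another kind at this position, such as an amine or a carboxylic acid, would also stay within the scatter. They also leave open whether the exchange to trifluoromethyl would give a similar step on the shorter chain of compound 3.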